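Aryl Swap on a Triazole Ester Side Chain

This account rests on a few compounds, and the source may have more. Where it says the series, first, only, none or still open, it means among the compounds named here.

Measured compounds:
Compound 1, `C#CCOC(=O)/C(C)=C/CC/C(C)=C/CC/C(C)=C/CC[C@@H]1[C@@]2(C)CCC(=O)C(C)(C)[C@H]2CC[C@@]1(C)O`, gives 45100 nM.
Compound 2, `C/C(=C\CC/C(C)=C/CC[C@@H]1[C@@]2(C)CCC(=O)C(C)(C)[C@H]2CC[C@@]1(C)O)CC/C=C(\C)C(=O)OCc1cn(-c2cccc(Br)c2)nn1`, reaches only a limit of the assay, > 150000 nM.

For the measured compounds named here, in a functional assay on A549 cells (Homo sapiens) for antiproliferative activity, read by MTT assay, with a stated time of 48 h (on this read-out lower numbers stand for stronger inhibition and higher numbers for weaker inhibition), compound 1 is the one compound with a true number. Compound 2 sits at the assay limit, (the limit of > 150000 nM in this assay, at which 1 of the 2 values shown sits), and therefore stands only as a lower bound among the numbers shown. Going by the values given here, the single measured step, an at least 3.3-fold higher number from compound 1 to compound 2 (0.52 log units; beyond the scatter), introduced 1-(3-bromophenyl)-1H-1,2,3-triazol-4-yl in place of ethynyl and pushed the read-out to the limit.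

Compound 3, `C/C(=C\CC/C(C)=C/CC[C@@H]1[C@@]2(C)CCC(=O)C(C)(C)[C@H]2CC[C@@]1(C)O)CC/C=C(\C)C(=O)OCc1cn(-c2ccccc2Cl)nn1`, differs from compound 2 by 2-chlorophenyl in place of 3-bromophenyl on an aromatic nitrogen. Among the compounds with values here, no measured step touches a change of one aryl group for another on the triazole nitrogen, so the move from compound 2 to compound 3 has no direct precedent. Within the data shown here, the only guidance is that compound 2 is already beyond the measurable range, so compound 3 is expected to remain in the same region, most probably again at the limit. The change expected for compound 3 is a number no higher from compound 2 to compound 3 (the limit leaves the size open), meaning no step beyond the scatter. Compound 3 is estimated at 150000 nM, with a range from 40000 nM to 400000 nM.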

Compound 3, half-maximal inhibitory concentration: > 150000 nM
Compound 3 was reported as a limit; the forecaster's own chance of this, stated with the estimate: 65%; the middle value sits exactly at the limit.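

In this assay, compound 3 gives > 150000 nM, which is again a limit of the assay and not a number. Setting 1-(2-chlorophenyl)-1H-1,2,3-triazol-4-yl in place of ethynyl produces an at least 3.3-fold higher number from compound 1 to compound 3 (0.52 log units; beyond the scatter), so the loss of activity seen with the 3-bromophenyl group is not confined to that one aryl group: it recurs when 2-chlorophenyl sits on the same aromatic nitrogen. The step between compound 2 and compound 3 cannot be read, and the two aryl groups cannot be ranked, because both compounds sit at the same ceiling: the limit of > 150000 nM in this assay, at which 2 of the 3 values shown sit.

The compounds shown leave open whether any aryl group on this nitrogen can give a true number, and whether a benzyl or methyl group there, or an amine on the phenyl ring, would bring the read-out back within the measurable range. Also open, as far as these compounds go, is whether the loss belongs to the triazole itself or to the aryl group it carries, and whether an amide in place of the ester would change the picture.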